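The source may hold more compounds than are shown below. What is called first, only, known or untested is meant among the compounds shown, and "the series" means these compounds.

Measured so far:
- compound 1 `COc1ccc(NS(=O)(=O)c2cccc([N+](=O)[O-])c2)cc1N1CCN(C)CC1` gives 79.4 nM in an assay on HeLa cells for binding affinity to 5-hydroxytryptamine receptor 6 (Homo sapiens); a higher number here means a weaker inhibitor, a lower number a stronger inhibitor
- compound 2 `COc1ccc(NS(=O)(=O)c2cccc(I)c2)cc1N1CCN(C)CC1` gives 0.794 nM in this assay

Compound 2 stands at the lower of the two numbers, and the step between them is a 100-fold lower number from compound 1 to compound 2 (2.00 log units; beyond the scatter), a large change from a single swap of one aromatic substituent for another. Compound 3 `COc1ccc(NS(=O)(=O)c2cn(C)cn2)cc1N1CCN(C)CC1` has not yet been measured. Its difference from compound 2 is 1-methyl-1H-imidazol-4-yl in place of 3-iodophenyl on a sulfonyl sulfur: the whole six-membered ring with its iodine gives way to a smaller five-membered ring with two nitrogen atoms. Among the compounds with values here, no measured step bears on this kind of change; the one known step, from nitro to iodo, shows only that what sits on the sulfonyl can move the number a great deal. Because compound 2 sits at 0.794 nM and the iodine it carries is removed here, a weakening step of a 25-fold higher number from compound 2 to compound 3 (1.40 log units; beyond the scatter) is expected. Compound 3 is therefore estimated at 20 nM, with a range from 2 nM to 200 nM.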

Compound 3, inhibition constant: 794 nM
For compound 3 the middle estimate is 40-fold (1.60 log units) below the measured one, outside the stated range (above it).
By their numbers in this assay, from the lowest: compound 2; then compound 1; then compound 3.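

Putting 1-methyl-1H-imidazol-4-yl on the sulfonyl sulfur in place of the 3-iodophenyl ring gives a 1000-fold higher number from compound 2 to compound 3 (3.00 log units; beyond the scatter) in this assay and so shows that replacing the whole ring can move the number even further than the earlier swap of one substituent. Measured against the 3-nitrophenyl ring, the same change gives a 10-fold higher number from compound 1 to compound 3 (1.00 log units; beyond the scatter) and places this five-membered ring behind both six-membered rings shown, not only the one carrying iodine. Nothing measured here explains why this ring change has such an effect.

The compounds shown leave open whether the loss follows the change of ring or the loss of the iodine, a question that a plain phenyl ring on the same sulfur could help to settle. From the compounds shown here alone, how a 3-bromophenyl or a pyridine ring would compare also remains open.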